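Working notes: cyclohexyl to isopropyl on the shared core

A few compounds are considered here, and "the series" means these few. Any claim that something is new, unique, unknown or untested is made for them only; others in the source may bear on it.

compound 1 `Cc1c(Cc2ccccc2)c(=O)c2cc(Cl)ccc2n1C` gives 2000 nM
compound 2 `COc1cc2[nH]c(C)c(C3CCCCC3)c(=O)c2cc1Cl` gives 5000 nM
compound 3 `COc1cc2[nH]c(C)c(C(C)C)c(=O)c2cc1Cl` has no value yet

In a physicochemical assay for solubility, read by HPLC, at pH 7.4 (on this read-out lower numbers stand for lower solubility and higher numbers for higher solubility), compound 2 reads 5000 nM and holds the higher of the two numbers. Compound 1 reads 2000 nM on the same read-out. The gap between these two numbers lies beyond the scatter. Going by the values given here, these two compounds differ in more than one place, so no measured step isolates a single change, and their gap cannot be assigned to any one group.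

Compound 3 keeps the core of compound 2 and changes one group. The change isopropyl in place of cyclohexyl on an aromatic carbon sits on an aromatic carbon, ortho to a methyl group and two atoms from the ring nitrogen. In words, isopropyl stands in place of cyclohexyl. Among the compounds with values here, no measured pair covers this change, so the expectation is a judgement with wide bounds. A modest upward move in this assay is expected, slightly beyond the scatter. The estimated size is a 2.4-fold higher number from compound 2 to compound 3 (0.38 log units; beyond the scatter) on this reading. The estimate for compound 3 is 12000 nM with an expected range from 4000 nM to 40000 nM as working bounds.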

Compound 3, solubility: > 20000 nM
Compound 3: only a limit was reported; the forecaster's own chance of this, stated with the estimate: 5%; at least 1.6-fold (0.22 log units) between middle value and limit.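

In this assay, going by these compounds alone, isopropyl in place of cyclohexyl on an aromatic carbon gives an at least 4.0-fold higher number from compound 2 to compound 3 (0.60 log units; beyond the scatter), the only measured step here that isolates one change, which shows that the read-out responds to the group at this position on the shared core. Compound 3 reads > 20000 nM, a limit of the assay and not a number. The printed step is therefore a floor, and its true size cannot be read from these data: the limit of > 20000 nM in this assay, at which 1 of the 3 values shown sits.

The compounds shown leave open whether the step follows the loss of the six-membered ring or the smaller count of heavy atoms, since cyclohexyl and isopropyl differ in both, and a cyclopropyl or tert-butyl group at this aromatic carbon would help to separate the two. They also leave open whether the same change would give a similar step on another core, and how a group of a different kind, such as an amine or a carboxylic acid, would read at this position.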